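The source may hold more compounds than are shown below. What is called first, only, known or untested is meant among the compounds shown, and "the series" means these compounds.

Compound 1, `CC(C)(C)OC(=O)NCCCCNC(=O)CN1CN(c2ccccc2)C2(CCN(C(=O)c3ccc(C(C)(C)C)cc3)CC2)C1=O`, belongs to the same series, but in an assay on HEK293 cells for displacement of a labelled ligand from NPC1-like intracellular cholesterol transporter 1 (Homo sapiens) (on this read-out higher numbers stand for weaker inhibition and lower numbers for stronger inhibition), compound 1 gives "not determined" (no result reported). Compound 2, `CC(C)(C)c1ccc(C(=O)N2CCC3(CC2)C(=O)N(CC(=O)N2CCCCC2CCO)CN3c2ccccc2)cc1`, gives 6100 nM in this assay. Compound 3, `CC(C)(C)c1ccc(C(=O)N2CCC3(CC2)C(=O)N(CC(=O)NCCN)CN3c2ccccc2)cc1`, gives 7000 nM in this assay; among the two numbers available it stands beside compound 2, and the two cannot be separated, since there is a 1.1-fold higher number from compound 2 to compound 3 (0.06 log units; within the scatter). Compound 4, `CCOC(=O)C1CCN(C(=O)CN2CN(c3ccccc3)C3(CCN(C(=O)c4ccc(C(C)(C)C)cc4)CC3)C2=O)CC1`, has not yet been measured in this assay. It differs from compound 3 in one place: 4-(ethoxycarbonyl)piperidin-1-yl in place of (2-aminoethyl)amino on a carbonyl carbon.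

Among the compounds with values here, the only measured step that bears on this position is the one from compound 2 to compound 3, which exchanged 2-(2-hydroxyethyl)piperidin-1-yl for (2-aminoethyl)amino on the same carbonyl carbon and left the number within the scatter. Compound 2 thus already shows that a piperidin-1-yl substituent on this carbonyl carbon gives about the same number as the open-chain (2-aminoethyl)amino of compound 3. On that basis no step beyond the scatter is expected for compound 4, that is a 1.1-fold lower number from compound 3 to compound 4 (0.03 log units; within the scatter). Compound 4 is therefore estimated at 6500 nM in this assay, with a range from 2500 nM to 17000 nM.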

Compound 4, half-maximal inhibitory concentration: 3100 nM
Compound 4: middle estimate off by 2.1-fold (0.32 log units), on the high side; the range from low to high includes it.
By their numbers in this assay, from the lowest: compounds 4, 2 and 3 (each within the scatter of the next, the first and the last beyond it).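

In this assay, within the data shown here, placing 4-(ethoxycarbonyl)piperidin-1-yl on this carbonyl carbon instead of (2-aminoethyl)amino gives a 2.3-fold lower number from compound 3 to compound 4 (0.35 log units; beyond the scatter) and so provides the first measured step at this position that clears the scatter, though only modestly. The comparison with the other ring-bearing group, 2-(2-hydroxyethyl)piperidin-1-yl, gives a 2.0-fold lower number from compound 2 to compound 4 (0.29 log units; within the scatter) and so does not separate these two piperidin-1-yl substituents, while showing that this position accepts a substituent with 0 hydrogen-bond donors and an ethoxycarbonyl group without any rise in the number. No measurement available here explains why the number falls from the open chain to this ring.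

As far as these compounds go, whether the step comes from the piperidine ring or from its ethoxycarbonyl group stays open, and a plain piperidin-1-yl and a 4-carboxypiperidin-1-yl on the same carbonyl carbon would help to tell these apart. From the compounds shown here alone, how a longer chain ending in a free amine would compare also stays open, and compound 1 with its longer chain gives "not determined" (no result reported) in this assay and so offers no guide.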